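The compounds below may be only part of what the source reports. "The series", "measured", "known", "first", "only" and "open" are said of these compounds alone.

Measured compounds:
compound 1, `COc1ccc([C@@H]2C(c3cc4ccccc4n3C)C(=O)N2c2cc(OC)c(OC)c(OC)c2)cc1`, 6600 nM
compound 2, `COc1ccc(C2/C(=C/c3ccc(C)s3)C(=O)N2c2cc(OC)c(OC)c(OC)c2)cc1`, 580 nM

In a functional assay on MCF7 cells (Homo sapiens) for antiproliferative activity, read by MTT assay (on this read-out higher numbers stand for weaker inhibition and lower numbers for stronger inhibition), compound 1 gives 6600 nM, the highest of the two numbers; compound 2, the nearest, gives 580 nM, a lower number by a margin beyond the scatter. Compound 3, `COc1ccc([C@@H]2C(C3CCCCC3)C(=O)N2c2cc(OC)c(OC)c(OC)c2)cc1`, is not yet measured. It differs from compound 1 by cyclohexyl in place of 1-methyl-1H-indol-2-yl on a saturated ring carbon. Among the compounds with values here, no measured pair shows this change, so its step size is unknown. Compound 3 is expected in this assay to move a step of a 1.4-fold higher number from compound 1 to compound 3 (0.13 log units; within the scatter) toward a weaker number, likely within the scatter. Compound 3 is estimated at 9000 nM, within 2500 nM to 40000 nM.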

Compound 3, half-maximal inhibitory concentration: 580 nM
Compound 3: middle estimate off by 16-fold (1.19 log units), on the high side; measured number outside the range, below it.
By their numbers in this assay, from the lowest: compounds 2 and 3 (each within the scatter of the next); then compound 1.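

In this assay, cyclohexyl in place of 1-methyl-1H-indol-2-yl on the saturated ring carbon gives an 11-fold lower number from compound 1 to compound 3 (1.06 log units; beyond the scatter) and so shows that this position is sensitive to the group it carries. It also shows that, on this core, the two aromatic rings of compound 1 are not required at this position for the lower number. Nothing available here accounts for the size of this step. The compounds shown leave open how a plain phenyl, a cyclopentyl, a piperidine or an open butyl chain would read at this position.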